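The source may hold more compounds than are shown below. What is called first, only, known or untested is meant among the compounds shown, and "the series" means these compounds.

Measured so far:
compound 1 `Cc1ccc(NC(=O)N[C@H]2CC[C@H](Oc3ccc(F)cc3)CC2)cc1` — > 20000 nM
compound 2 `CSc1ccccc1NC(=O)N[C@H]1CC[C@H](Oc2ccc(F)cc2)CC1` — > 20000 nM

In a functional assay on CRL2813 cells (Homo sapiens) for cytotoxicity, read by sulforhodamine B assay, with a stated time of 5 days (a higher number here means a weaker inhibitor, a lower number a stronger inhibitor), compound 1 reaches only the limit of the assay, > 20000 nM. In this assay compound 2 likewise reaches only the limit, > 20000 nM. The step that the two limits leave unreadable from compound 1 to compound 2 is therefore unreadable, since both values are limits; this is summed up by the limit of > 20000 nM in this assay, at which 2 of the 2 values shown sit, at which both measured values sit.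

Compound 3 `COc1cccc(NC(=O)N[C@H]2CC[C@H](Oc3ccc(F)cc3)CC2)c1` differs from compound 2 by 3-methoxyphenyl in place of 2-(methylsulfanyl)phenyl on an amide-type nitrogen. Within the data shown here, the only measured step bearing on this change is unreadable, so no direction or size can be drawn from it. Given that compound 2 sits at the limit with > 20000 nM, compound 3 is expected to remain near or beyond that limit, with an expected step that the limit leaves unreadable from compound 2 to compound 3 in this assay of no readable size. Compound 3 is thus estimated at 40000 nM, within 15000 nM to 150000 nM.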

Compound 3, half-maximal inhibitory concentration: 14000 nM
Compound 3: the middle estimate sits 2.9-fold (0.46 log units) above what was measured; measured number outside the range, below it.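

Compound 3, with 3-methoxyphenyl on the amide-type nitrogen, is the only compound shown with a measured number rather than a limit in this assay, so this position can give a readable value. The change gives an at least 1.4-fold lower number from compound 2 to compound 3 (0.15 log units; that floor lies within the scatter) when 3-methoxyphenyl replaces 2-(methylsulfanyl)phenyl, and an at least 1.4-fold lower number from compound 1 to compound 3 (0.15 log units; that floor lies within the scatter) when it replaces 4-methylphenyl. Both steps are only floors and neither floor clears the scatter, so their true size stays unknown, since the other two values remain at a limit: the limit of > 20000 nM in this assay, at which 2 of the 3 values shown sit.

The compounds shown do not tell whether the readable value follows the methoxy group itself or its placement as 3-methoxyphenyl, a question that 2-methoxyphenyl and 4-methoxyphenyl would bear on. On these data alone, it also remains open how an amine or a carboxylic acid on this phenyl ring would read in this assay.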